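The source may hold more compounds than are shown below. What is called first, only, known or untested is meant among the compounds shown, and "the series" means these compounds.

Measured compounds:
Compound 1, `COc1cc(Cl)ccc1C(=S)Nc1ccc(Cl)cc1O`, gives 5110 nM in a functional assay on HepG2 cells (Homo sapiens) for cytotoxicity, with a stated time of 24 h; on this read-out lower numbers stand for stronger inhibition and higher numbers for weaker inhibition.
Compound 2, `COc1cc(Cl)ccc1C(=S)Nc1cc(Cl)ccc1O`, gives 8490 nM in this assay.
Compound 3, `COc1cc(Cl)ccc1C(=S)Nc1ccc(Br)cc1O`, gives 3880 nM in this assay.

Compound 3 arises from compound 1 by one change, (bromo in place of chloro on an aromatic carbon), and the step is a 1.3-fold lower number from compound 1 to compound 3 (0.12 log units; within the scatter). Compound 2 has the same atoms as compound 1 joined differently; how the two cores differ is not broken down here. Compound 2 stands beyond the scatter of compound 3 only, so its number is higher than that of compound 3.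

Compound 4, `COc1cc(Cl)ccc1C(=S)Nc1cc(Br)ccc1O`, is not yet measured. It arises from compound 2 by bromo in place of chloro on an aromatic carbon, the same kind of change as from compound 1 to compound 3, though the place differs: here meta to a large group and para to a hydroxy group, there meta to a hydroxy group and para to a large group. Because a 1.3-fold lower number from compound 1 to compound 3 (0.12 log units; within the scatter) is within the scatter, a similarly small step is expected, a 1.3-fold lower number from compound 2 to compound 4 (0.12 log units; within the scatter). Compound 4 is thus estimated at 6500 nM, between 3000 nM and 13000 nM.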

Compound 4, half-maximal inhibitory concentration: 6530 nM
Beside the measured number, compound 4's estimate is 1.0-fold (0.00 log units) below it; the range from low to high includes it.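

In this assay, bromo in place of chloro on an aromatic carbon gives a 1.3-fold lower number from compound 2 to compound 4 (0.11 log units; within the scatter) on the core of compound 2. Set beside the earlier step, the change carries from one core to the other with no difference that can be told apart: the same change on two cores in this assay, a 1.3-fold lower number (0.12 log units; within the scatter) from compound 1 to compound 3 and a 1.3-fold lower number (0.11 log units; within the scatter) from compound 2 to compound 4, 1.0-fold (0.01 log units) apart, within the scatter of two such steps.
This holds for these two cores only, each with the halogen at its own place, and as both steps lie within the scatter, it does not show that bromo and chloro differ on this read-out.

The compounds shown leave open what a group other than these two halogens, such as fluoro, methyl or nitrile, would do at the same place. They also leave open whether an amine could stand in place of the hydroxy group.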